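Hydroxy to methoxy step on two amide cores

The compounds below may be only part of what the source reports. "The series", "measured", "known", "first", "only" and "open" are said of these compounds alone.

Measured values in a functional assay on NCI-H226 cells (Homo sapiens) for inhibition, read by sulforhodamine B assay, with a stated time of 48 h, tested at 10 uM; a lower number here means a stronger effect, a higher number a weaker effect of the compound at the concentration tested:

compound 1 `O=C(Nc1cccc(-n2cc(-c3ccncc3)c(-c3cc(O)cc(Cl)c3)n2)c1)Nc1ccc(Cl)c(Cl)c1` gives 14.5%
compound 2 `COc1cc(Cl)cc(-c2nn(-c3cccc(NC(=O)Nc4ccc(Cl)c(Cl)c4)c3)cc2-c2ccncc2)c1` gives 7.27%
compound 3 `O=C(Nc1cccc(-n2cc(-c3ccncc3)c(-c3cc(O)cc(Cl)c3)n2)c1)c1cc(C(F)(F)F)cc(C(F)(F)F)c1` gives 96%

Compound 1 and compound 2 share one core and differ only by methyl in place of hydrogen on an oxygen on an aromatic ring; in this assay the step of a number 7.2 percentage points lower from compound 1 to compound 2 (within the scatter). Compound 3 carries a different core; the difference between the cores of compound 1 and compound 3 is not broken down here, and in this assay compound 3 stands highest of the three, with a gap to compound 1 and to compound 2 that lies beyond the scatter.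

Compound 4 `COc1cc(Cl)cc(-c2nn(-c3cccc(NC(=O)c4cc(C(F)(F)F)cc(C(F)(F)F)c4)c3)cc2-c2ccncc2)c1` has not been measured. Among the measured compounds shown here, it differs from compound 3 by methyl in place of hydrogen on an oxygen on an aromatic ring, which is the same change as the one from compound 1 to compound 2: the place lines agree word for word, the group that leaves and the group that enters are the same. For the measured compounds named here, the only measured instance of this change, a number 7.2 percentage points lower from compound 1 to compound 2 (within the scatter), stayed within the scatter, so no real shift is expected from it on the core of compound 3 either. The expectation for compound 4 therefore rests on the value of compound 3, 96%, and the step of a number 4 percentage points lower from compound 3 to compound 4 (within the scatter) is estimated to be small. In this assay compound 4 is expected to give about 92%, with 76% to 106% as the likely range; this is an estimate, drawn from one earlier instance of the change on another core.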

Compound 4, a percentage reported as activity, at one concentration (the size of the read-out at that concentration, not a potency): 76%
Beside the measured number, compound 4's estimate is 16 percentage points above it; the range from low to high includes it.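

In this assay, the hydroxy to methoxy change on the core of compound 3 gives a number 20 percentage points lower from compound 3 to compound 4 (beyond the scatter), so on this core the change has a measurable effect on the read-out at the concentration tested. Set beside the earlier instance of the same change, the two steps run in the same direction and cannot be told apart in size: the same change on two cores in this assay, a number 7.2 percentage points lower (within the scatter) from compound 1 to compound 2 and a number 20 percentage points lower (beyond the scatter) from compound 3 to compound 4, 12.8 percentage points apart, within the scatter of two such steps. This supports carrying the change from one core to the other as a working assumption, but it rests on two pairs only, one step lies within the scatter and the other beyond it, and two pairs cannot fix a common size for the step or show that it would hold on a further core.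

The compounds shown leave open whether a longer chain on that oxygen, such as ethyl or propyl, or an amine in place of the hydroxy, would follow the same course on either core. They also leave open whether the change would give a stronger or weaker effect at any other concentration: each value here is the size of the read-out at a single concentration.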